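This account rests on a few compounds, and the source may have more. Where it says the series, first, only, none or still open, it means among the compounds named here.

Measured compounds:
compound 1, `CC(=O)O[C@H]1CC[C@]2(C)[C@H](CC[C@@](C)(O)[C@H]2CC[C@@H]2C(C)=CC[C@H]3[C@H](CC[C@]3(C)O)C2(C)C)OC1(C)C`: 47900 nM
compound 2, `CC1=CC[C@H]2[C@H](CC[C@]2(C)O)C(C)(C)[C@@H]1CC[C@H]1[C@]2(C)CC/C(=N/OC(=O)c3ccccc3)C(C)(C)O[C@H]2CC[C@@]1(C)O`: 25600 nM

Within the data shown here, in a functional assay on MCF7 cells (Homo sapiens) for antiproliferative activity, read by MTT assay, with a stated time of 72 h (a lower number here means a stronger inhibitor, a higher number a weaker inhibitor), compound 1 gives 47900 nM, the highest of the two numbers so far. Its nearest neighbour is compound 2, which in this assay gives 25600 nM; the gap between the two lies within the scatter, so nothing separates them. Compound 3, `CC1=CC[C@H]2[C@H](CC[C@]2(C)O)C(C)(C)[C@@H]1CC[C@H]1[C@]2(C)CC[C@H](OC(=O)c3ccccc3[N+](=O)[O-])C(C)(C)O[C@H]2CC[C@@]1(C)O`, shares the core of compound 1 and differs from it in one place: 2-nitrophenyl in place of methyl on a carbonyl carbon. Among the measured compounds shown here, no step between two measured compounds of this kind is available, so the effect of the change can only be judged from what compound 1 and compound 2 show. Compound 3 is expected to move by a 1.6-fold lower number from compound 1 to compound 3 (0.20 log units; within the scatter), a small shift toward a lower number that is unlikely to exceed the scatter. Compound 3 is estimated at 30000 nM, with a range from 10000 nM to 90000 nM.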

Compound 3, half-maximal inhibitory concentration: 5200 nM
Compound 3: the middle estimate sits 5.8-fold (0.76 log units) above what was measured; measured number outside the range, below it.
By their numbers in this assay, from the lowest: compound 3; then compounds 2 and 1 (each within the scatter of the next).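

In this assay the exchange of methyl for 2-nitrophenyl on a carbonyl carbon gives a 9.2-fold lower number from compound 1 to compound 3 (0.96 log units; beyond the scatter) and so stands beyond the scatter. Among these compounds, this is the first sign that the number responds to what is carried at this position on the shared core, which the two earlier values, lying within the scatter of each other, could not show. Nothing at hand accounts for the size of this step.

Among the compounds shown here, the single step brings in the aromatic ring and the nitro group together, so it leaves open which of the two goes with the lower number. On these data alone, whether a plain phenyl, a phenyl bearing an amine or a carboxylic acid, or a longer alkyl chain in place of methyl would give a similar number also remains open.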